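Notes on a trimethoxyphenyl series: from compound 3 to compound 4

The compounds below may be only part of what the source reports. "The series", "measured", "known", "first", "only" and "open" are said of these compounds alone.

Compound 1 `COc1cc(-c2ccnc3cc(-c4ccc(C(C)=O)cc4)nn23)cc(OC)c1OC` gives 3930 nM in a functional assay on B16-F0 cells (Mus musculus) for inhibition, read by CCK-8 assay, with a stated time of 48 h; a higher number here means a weaker inhibitor, a lower number a stronger inhibitor.
Compound 2 `Cc1ccc(-c2cc3nccc(-c4ccc(F)cc4)n3n2)cc1` gives only a limit of this assay, > 10000 nM.
Compound 3 `COc1cc(-c2ccnc3cc(-c4ccc5cnn(C)c5c4)nn23)cc(OC)c1OC` gives 1000 nM in this assay.

Compound 3 stands at the lowest of the two numbers shown; its nearest neighbour is compound 1, and the only measured step, a 3.9-fold lower number from compound 1 to compound 3 (0.59 log units; beyond the scatter), bears on the change now considered. The reading of compound 2 sits at the limit of > 10000 nM in this assay, at which 1 of the 3 values shown sits, and adds no number.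

Compound 4 `C=Cc1ccc(-c2cc3nccc(-c4cc(OC)c(OC)c(OC)c4)n3n2)cc1` differs from compound 3 by 4-vinylphenyl in place of 1-methyl-1H-indazol-6-yl on an aromatic carbon. Because a 3.9-fold lower number from compound 1 to compound 3 (0.59 log units; beyond the scatter) was gained when 1-methyl-1H-indazol-6-yl replaced 4-acetylphenyl, its removal in favour of 4-vinylphenyl is expected to send the number back up toward that of compound 1. Compound 4 is therefore estimated at 3500 nM, with a range from 1200 nM to 10000 nM. This estimate means an expected step of a 3.5-fold higher number from compound 3 to compound 4 (0.54 log units; beyond the scatter).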

Compound 4, half-maximal inhibitory concentration: 788 nM
The estimate for compound 4 lay 4.4-fold (0.65 log units) above the measured number; the measured number lies below the stated range.
By their numbers in this assay, from the lowest: compounds 4 and 3 (each within the scatter of the next); then compound 1. At a limit, above all of these: compound 2.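

In this assay, replacing 1-methyl-1H-indazol-6-yl with 4-vinylphenyl gives a 1.3-fold lower number from compound 3 to compound 4 (0.10 log units; within the scatter), so for compounds 3 and 4 the two nitrogen atoms of the group that leaves are not needed to hold the reading at this position. With the same 4-substituted phenyl arrangement, vinyl in place of acetyl gives a 5.0-fold lower number from compound 1 to compound 4 (0.70 log units; beyond the scatter), so the group on that phenyl ring does change the reading. Nothing measured here accounts for either step. As far as these compounds go, what an amine or a carboxylic acid in place of vinyl would give remains open.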